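The source may report more compounds than this note shows. Statements on the series, on what has been measured and on what is new or still open speak of the compounds shown alone.

Measured compounds:
- compound 1, `O=C1C=CCC(/C=C/c2ccccc2)N1`: 967 uM
- compound 2, `O=C1C=CCC(/C=C/c2ccc(C(F)(F)F)cc2)N1`: 71.8 uM

In a functional assay on NCI/ADR cells (Homo sapiens) for inhibition, read by sulforhodamine B assay, with a stated time of 48 h (on this read-out higher numbers stand for weaker inhibition of growth and lower numbers for stronger inhibition of growth), compound 1 gives 967 uM, and compound 2 gives 71.8 uM. Going by the values given here, the single step between them, a 13-fold lower number from compound 1 to compound 2 (1.13 log units; beyond the scatter), is the only step measured so far. Compound 2 therefore stands at the lowest number of the two, with compound 1 at a higher number beyond the scatter.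

Compound 3, `COc1ccc(/C=C/C2CC=CC(=O)N2)cc1`, is not yet measured. It differs from compound 2 in one place: methoxy in place of trifluoromethyl on an aromatic carbon. The methoxy sits on an aromatic carbon of the six-membered aromatic ring of carbon only, para to a group of 9 heavy atoms.

Among the compounds with values here, no measured step shows what a methoxy does here. The step that bears on the position is a 13-fold lower number from compound 1 to compound 2 (1.13 log units; beyond the scatter), which shows that the group on this carbon matters strongly. Whether a methoxy behaves like a trifluoromethyl or like a hydrogen cannot be read from these two compounds. The account therefore expects compound 3 to land between them, nearer compound 1 than compound 2, in a step of a 4.2-fold higher number from compound 2 to compound 3 (0.62 log units; beyond the scatter). Compound 3 is thus estimated at 300 uM, with a range from 90 uM to 1000 uM.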

Compound 3, concentration for growth inhibition (reported as GI): 842 uM
For compound 3 the middle estimate is 2.8-fold (0.45 log units) below the measured one, within the range that was stated.
By their numbers in this assay, from the lowest: compound 2; then compounds 3 and 1 (each within the scatter of the next).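

In this assay, methoxy in place of trifluoromethyl gives a 12-fold higher number from compound 2 to compound 3 (1.07 log units; beyond the scatter), so the low number of compound 2 does not carry over to this other group on the same aromatic carbon. Methoxy in place of hydrogen gives a 1.1-fold lower number from compound 1 to compound 3 (0.06 log units; within the scatter), which means that on this read-out the methoxy cannot be told apart from hydrogen here, and that putting a group on this carbon does not by itself shift the number; among these three compounds, only the trifluoromethyl compound stands apart. Nothing given here accounts for the difference between the two groups.

From the compounds shown here alone, with only hydrogen, methoxy and trifluoromethyl compared at this carbon, it remains open what sets trifluoromethyl apart, and whether a chlorine atom, a nitrile or an amine at the same place would track compound 2 or compound 3. Going by these compounds, it also remains open whether the trifluoromethyl step would hold with the group on another carbon of the aromatic ring, or with any change to the rest of the shared core.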